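A thiophen-2-yl swap on a carbonyl carbon

This account rests on a few compounds, and the source may have more. Where it says the series, first, only, none or still open, it means among the compounds named here.

compound 1 `O=c1[nH]c2ccc(Cl)cc2c(-c2ccccc2Cl)c1CCO` gives 380000 nM
compound 2 `CCOCC(=O)OCCc1c(-c2ccccc2Cl)c2cc(Cl)ccc2[nH]c1=O` gives 130000 nM
compound 3 `O=C(OCCc1c(-c2ccccc2Cl)c2cc(Cl)ccc2[nH]c1=O)c1cccnc1` gives 170000 nM

These numbers come from an ADME assay on HepG2 2.2.15 cells (Homo sapiens) for cytotoxicity; on this read-out lower numbers stand for higher toxicity in this test and higher numbers for lower toxicity in this test. Compound 3 stands within the scatter of compound 2, and both lie lower than compound 1. Compound 4 `O=C(OCCc1c(-c2ccccc2Cl)c2cc(Cl)ccc2[nH]c1=O)c1cccs1` has thiophen-2-yl in place of pyridin-3-yl on a carbonyl carbon. The closest evidence is the earlier exchange on that same carbonyl carbon (a 1.3-fold higher number from compound 2 to compound 3 (0.12 log units; within the scatter)), which stayed within the scatter. The two modest steps (a 2.9-fold lower number from compound 1 to compound 2 (0.47 log units; beyond the scatter)) and (a 2.2-fold lower number from compound 1 to compound 3 (0.35 log units; beyond the scatter)) replaced the hydrogen on the oxygen, a change that compound 4 shares with compound 3 and so does not repeat. For the measured compounds named here, no thiophen-2-yl compound has been measured yet, so the comparison rests on this one exchange. No step beyond the scatter is therefore expected in this assay and the estimated change is small (a 1.1-fold lower number from compound 3 to compound 4 (0.05 log units; within the scatter)). Compound 4 is expected at 150000 nM (range 75000 nM to 300000 nM).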

Compound 4, half-maximal cytotoxic concentration: > 1700000 nM
Compound 4: no number, only a limit; the forecaster's own chance of this, stated with the estimate: 5%; at least 11-fold (1.05 log units) between middle value and limit.
By their numbers in this assay, from the lowest: compounds 2 and 3 (each within the scatter of the next); then compound 1. At a limit, above all of these: compound 4.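

Compound 4 gives only a limit, not a number, in this assay: the limit of > 1700000 nM in this assay, at which 1 of the 4 values shown sits. On the carbonyl carbon, thiophen-2-yl in place of pyridin-3-yl gives an at least 10-fold higher number from compound 3 to compound 4 (1.00 log units; beyond the scatter), and thiophen-2-yl in place of ethoxymethyl gives an at least 13-fold higher number from compound 2 to compound 4 (1.11 log units; beyond the scatter), so this position, where the earlier exchange stayed within the scatter, can move the read-out well beyond it. Putting (thiophen-2-yl)carbonyl in place of the hydrogen on the oxygen gives an at least 4.4-fold higher number from compound 1 to compound 4 (0.65 log units; beyond the scatter), opposite in direction to the replacements in compound 2 and compound 3, so replacing that hydrogen does not lower the number in every case.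

From the compounds shown here alone, how far compound 4 lies past its limit stays open. Also open, going by these compounds, is whether the same shift would appear with thiophen-3-yl, furan-2-yl or phenyl on that carbonyl carbon.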